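The compounds below may be only part of what the source reports. "The series", "measured", "known", "first", "only" and "open" are said of these compounds alone.

Measured so far in an assay on COS-7 cells for inhibition of patatin-like phospholipase domain-containing protein 2 (Mus musculus); a lower number here means a stronger inhibitor, a higher number a weaker inhibitor:
compound 1 `CCOC(=O)c1cccc(-c2ccc(OCC)cc2)c1` gives 50000 nM
compound 2 `CCOC(=O)c1cccc(-c2ccc(OC)cc2)c1` gives 80000 nM
compound 3 `CCOC(=O)Nc1cccc(-c2ccc(N(C)C)cc2)c1` gives 3000 nM

Compounds 1 and 2 share one core; the change between them is methyl in place of hydrogen on a saturated chain carbon bound to an oxygen on an aromatic ring, and it gave a 1.6-fold lower number from compound 2 to compound 1 (0.20 log units; within the scatter). Compound 3 has another core; the difference between the two cores is not broken down here. Compound 3 gives the lowest number of the three, beyond the scatter from both compound 1 and compound 2, so it stands as the strongest inhibitor so far in this assay.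

Compound 4 `CC(C)OC(=O)Nc1cccc(-c2ccc(N(C)C)cc2)c1` is not yet measured. From compound 3 it differs by methyl in place of hydrogen on a saturated chain carbon bound to an oxygen next to a carbonyl group and a saturated chain carbon. This is the same kind of change as that from compound 2 to compound 1, but not the same: there the methyl entered on a saturated chain carbon bound to an oxygen on an aromatic ring, here on a saturated chain carbon bound to an oxygen next to a carbonyl group and a saturated chain carbon, and on a different core. In this assay, among the compounds with values here, the expected step is a 1.2-fold lower number from compound 3 to compound 4 (0.08 log units; within the scatter), because the only measured instance of this kind of change a 1.6-fold lower number from compound 2 to compound 1 (0.20 log units; within the scatter) stayed within the scatter. Compound 4 is estimated at 2500 nM, with a range from 1000 nM to 6000 nM.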

Compound 4, half-maximal inhibitory concentration: 82000 nM
Compound 4: the middle estimate sits 33-fold (1.52 log units) below what was measured; the measured number lies above the stated range.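

In this assay, the ethoxy to isopropoxy change gives a large step, a 27-fold higher number from compound 3 to compound 4 (1.44 log units; beyond the scatter). Set beside the earlier step, this kind of change, methyl in place of hydrogen on a saturated chain carbon bound to an oxygen, does not carry over between the two cores in this assay: the same change on two cores in this assay, a 1.6-fold lower number (0.20 log units; within the scatter) from compound 2 to compound 1 and a 27-fold higher number (1.44 log units; beyond the scatter) from compound 3 to compound 4, 44-fold (1.64 log units) apart, beyond the scatter of two such steps This shows that a step read on one of these cores cannot be applied to the other here, but it does not show which feature of the cores or of the two places of the methyl sets the steps apart, and one step per core gives no general rule for the series.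

Open, going by these compounds, is whether a tert-butyl group or a longer chain such as propyl on that oxygen of the core of compound 3 would give a number near that of compound 3 or near that of compound 4. Also open, on these data alone, is what an isopropoxy group in the ester of the core of compound 1 would give, which would put the same change at the same place on both cores.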